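Chloro to Methyl on the Aromatic Ring of Compound 1

A few compounds are considered here, and "the series" means these few. Any claim that something is new, unique, unknown or untested is made for them only; others in the source may bear on it.

Compound 1 `C[C@H]1CC[C@@H]2[C@@H](OC(=O)[C@]23CC(c2ccc(Cl)cc2)=NO3)[C@]2(C)C(=O)C=C[C@@]12O` was tested in a functional assay on SW-620 cells (Homo sapiens) for cytotoxicity, read by sulforhodamine B assay, with a stated time of 48 h (a lower number here means a stronger inhibitor, a higher number a weaker inhibitor), where compound 1 gives 51000 nM. Among the three compounds measured, compound 1 has the highest number, but the others sit close to it: compound 2 `C[C@H]1CC[C@@H]2[C@@H](OC(=O)[C@]23CC(c2ccccc2Br)=NO3)[C@]2(C)C(=O)C=C[C@@]12O` gives 44000 nM, and compound 3 `C[C@H]1CC[C@@H]2[C@@H](OC(=O)[C@]23CC(c2ccccc2)=NO3)[C@]2(C)C(=O)C=C[C@@]12O` gives 45400 nM. The steps of a 1.2-fold lower number from compound 1 to compound 2 (0.06 log units; within the scatter) and a 1.1-fold lower number from compound 1 to compound 3 (0.05 log units; within the scatter) both lie within the scatter, as does a 1.0-fold higher number from compound 2 to compound 3 (0.01 log units; within the scatter), so exchanging or removing the halogen on the aromatic ring has not shifted the read-out so far.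

Compound 4 `Cc1ccc(C2=NO[C@]3(C2)C(=O)O[C@@H]2[C@H]3CC[C@H](C)[C@]3(O)C=CC(=O)[C@@]23C)cc1` differs from compound 1 in a single place: methyl in place of chloro on an aromatic carbon. Going by the values given here, no measured step exchanges chloro for methyl directly, so the nearest guides are a 1.2-fold lower number from compound 1 to compound 2 (0.06 log units; within the scatter) and a 1.1-fold lower number from compound 1 to compound 3 (0.05 log units; within the scatter), in which a change on the same aromatic ring left the number within the scatter. On that basis the expected step is a 1.1-fold lower number from compound 1 to compound 4 (0.03 log units; within the scatter), with no shift beyond the scatter. Compound 4 is therefore estimated to give 48000 nM, within a range from 24000 nM to 96000 nM.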

Compound 4, half-maximal inhibitory concentration: 2500 nM
The estimate for compound 4 lay 19-fold (1.28 log units) above the measured number, outside the stated range (below it).
By their numbers in this assay, from the lowest: compound 4; then compounds 2, 3 and 1 (each within the scatter of the next).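

In this assay, this carbon proves able to move the number after all: a 20-fold lower number from compound 1 to compound 4 (1.31 log units; beyond the scatter) with methyl in place of chloro, and an 18-fold lower number from compound 3 to compound 4 (1.26 log units; beyond the scatter) with methyl in place of hydrogen, para to a large group. Compounds 1 and 3 read alike, so having a substituent at this carbon is not enough in itself; the change is tied to methyl among the groups shown, and an 18-fold lower number from compound 2 to compound 4 (1.25 log units; beyond the scatter) sets compound 4 apart from the 2-bromophenyl compound as well. Nothing measured here explains why methyl and chloro part so sharply.

From the compounds shown here alone, whether a longer chain such as ethyl, or a methoxy group, would carry the same gain at this carbon remains open. So does whether methyl would do the same on another carbon of the ring.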